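A few compounds are considered here, and "the series" means these few. Any claim that something is new, unique, unknown or untested is made for them only; others in the source may bear on it.

Compound 1 `COc1ccc(CN(C(=O)C(C)Br)c2cc(OC)c(OC)c(OC)c2)cc1O` is the most potent of the compounds with a number in a functional assay on MGC-803 cells (Homo sapiens) for inhibition, read by MTT assay, with a stated time of 48 h; a lower number here means a stronger inhibitor, a higher number a weaker inhibitor: compound 1 gives 120 nM. It stands lowest of the two numbers measured. The nearest is compound 3 `COc1ccc(N(Cc2cc(OC)c(OC)c(OC)c2)C(=O)CN=[N+]=[N-])cc1O`, which in this assay gives 22400 nM, a gap far beyond the scatter of the method. Compound 2 `COc1cc(NCc2ccc(Cl)cc2)cc(OC)c1OC` reaches only a limit of the assay: in this assay compound 2 gives > 80000 nM, which is a limit and not a number. One of the three values shown sits at this limit (the limit of > 80000 nM in this assay, at which 1 of the 3 values shown sits).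

Compound 4 `C/C=C/C(=O)N(Cc1ccc(OC)c(O)c1)c1cc(OC)c(OC)c(OC)c1` has not yet been measured in this assay. It differs from compound 1 in a single place: prop-1-en-1-yl in place of 1-bromoethyl on a carbonyl carbon. Among the measured compounds shown here, no pair of measured compounds differs by one change, so no measured step is available to calibrate this substitution, and the expectation rests on compound 1 alone, whose value in this assay is 120 nM.

The step that the estimate means, a 2.5-fold higher number from compound 1 to compound 4 (0.40 log units; beyond the scatter), is expected to be small, within or just beyond the usual scatter, and if anything toward a weaker number. Compound 4 is expected to give about 300 nM in this assay, in a range from 60 nM to 1500 nM.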

Compound 4, half-maximal inhibitory concentration: 27 nM
For compound 4 the middle estimate is 11-fold (1.05 log units) above the measured one; measured number below the stated range.
By their numbers in this assay, from the lowest: compound 4; then compound 1; then compound 3. At a limit, above all of these: compound 2.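

In this assay, the carbonyl carbon bonded to the amide-type nitrogen proves open to change: replacing 1-bromoethyl with prop-1-en-1-yl gives a 4.4-fold lower number from compound 1 to compound 4 (0.65 log units; beyond the scatter), a modest step but one beyond the scatter. Bromine is therefore not required for a low number at this position, and the new group, with one double bond outside aromatic rings, gives a lower number than the group it replaces. No measurement shown bears on why this change lowers the number.

The compounds shown cannot separate the effect of losing bromine from that of gaining the double bond, and a saturated propyl chain on the same carbonyl carbon would help to tell those two apart. They also leave open how far this position extends to other groups, such as a 1-chloroethyl group, a longer chain with a double bond, or a chain that ends in an amine, and whether any of them would keep a number as low as that of compound 4.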